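A Sulfanyl Chain Variation on the Pyridine-Bearing Antagonist Series

A few compounds are considered here, and "the series" means these few. Any claim that something is new, unique, unknown or untested is made for them only; others in the source may bear on it.

The series rests on a shared core carrying a fluorinated methanesulfonamide aryl group, and it was tested in an assay on cells for antagonist activity at transient receptor potential cation channel subfamily V member 1 (Homo sapiens), read by FLIPR and calcium flux, with a stated time of 6 min; a lower number here means a stronger inhibitor, a higher number a weaker inhibitor. Compound 1 `CC(C(=O)NCc1ccc(C(C)(C)C)nc1N1CCC(Cc2ccccc2)CC1)c1ccc(NS(C)(=O)=O)c(F)c1` gives 0.3 nM. Compound 2 `CCCCCCOc1nc(C(C)(C)C)ccc1CNC(=O)C(C)c1ccc(NS(C)(=O)=O)c(F)c1` gives 2.7 nM, which places it second highest among the three measured numbers; its nearest neighbour is compound 3 `CCCCSc1nc(C(C)(C)C)ccc1CNC(=O)C(C)c1ccc(NS(C)(=O)=O)c(F)c1`, which gives 3.2 nM, while compound 1 stands furthest away with a lower number beyond the scatter. The step from compound 2 to compound 3, butylsulfanyl in place of hexyloxy on an aromatic carbon, is a 1.2-fold higher number from compound 2 to compound 3 (0.07 log units; within the scatter).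

Compound 4 `CCCCCSc1nc(C(C)(C)C)ccc1CNC(=O)C(C)c1ccc(NS(C)(=O)=O)c(F)c1` has not yet been measured. It differs from compound 2 by pentylsulfanyl in place of hexyloxy on an aromatic carbon. Among the measured compounds shown here, the only measured step that bears on this change is the one from compound 2 to compound 3, which stayed within the scatter, and the pentylsulfanyl chain of compound 4 sits between the butylsulfanyl of compound 3 and the hexyloxy of compound 2 in length. No step beyond the scatter is therefore expected in this assay. Compound 4 is expected to give 2.8 nM, within a range of 1.3 nM to 6 nM. This estimate corresponds to an expected step of a 1.0-fold higher number from compound 2 to compound 4 (0.02 log units; within the scatter).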

Compound 4, inhibition constant: 3.1 nM
For compound 4 the middle estimate is 1.1-fold (0.04 log units) below the measured one; the range from low to high includes it.
By their numbers in this assay, from the lowest: compound 1; then compounds 2, 4 and 3 (each within the scatter of the next).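

The sulfur-linked chain now has two members at this position next to the ring nitrogen, and the direct exchange of hexyloxy for pentylsulfanyl in this assay gives a 1.1-fold higher number from compound 2 to compound 4 (0.06 log units; within the scatter). Extending the sulfanyl chain itself, with methyl in place of hydrogen on a saturated chain carbon, gives a 1.0-fold lower number from compound 3 to compound 4 (0.01 log units; within the scatter), so this change in chain length also stays within the scatter, which the earlier single step across both linking atom and chain length could not show separately. Nothing available here accounts for why these chains read alike.

As far as these compounds go, whether this holds for a much shorter chain such as methylsulfanyl, or for a chain ending in an amine or a carboxylic acid, remains open. So does the reading of a sulfonyl group in place of the sulfur.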